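A few compounds are considered here, and "the series" means these few. Any claim that something is new, unique, unknown or untested is made for them only; others in the source may bear on it.

Measured so far in a functional assay on MCF7 cells (Homo sapiens) for inhibition, read by MTT assay, with a stated time of 48 h; on this read-out lower numbers stand for stronger inhibition and higher numbers for weaker inhibition:
- compound 1 `Clc1ccc(-c2ccnc3c2c(-c2ccccc2)nn3-c2ccccc2)cc1`: 61100 nM
- compound 2 `O=C(C=CNc1cc(-c2ccccc2)nn1-c1ccccc1)c1ccccc1`: 9650 nM

Compound 1 has the higher of the two numbers, and so the weaker inhibition, with a gap to compound 2 that lies beyond the scatter. Compound 3 `Fc1ccc(-c2ccnc3c2c(-c2ccccc2)nn3-c2ccccc2)cc1` keeps the core of compound 1 and differs in one place: fluoro in place of chloro on an aromatic carbon. This is fluoro in place of chloro on an aromatic carbon, para to a large group. Going by the values given here, no measured pair shows this change, so no step beyond the scatter is expected in this assay. The expected change is a 1.1-fold lower number from compound 1 to compound 3 (0.05 log units; within the scatter). For compound 3 the estimated value is 55000 nM, with an expected range of 22000 nM to 130000 nM.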

Compound 3, half-maximal inhibitory concentration: 1570 nM
The estimate for compound 3 lay 35-fold (1.54 log units) above the measured number; the whole stated range lies above it.
By their numbers in this assay, from the lowest: compound 3; then compound 2; then compound 1.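

In this assay, the halogen of the 4-chlorophenyl group proves a sensitive point on the shared core: 4-fluorophenyl in its place gives a 39-fold lower number from compound 1 to compound 3 (1.59 log units; beyond the scatter). Exchanging one heavy atom, with no change in ring, hydrogen-bond donor or acceptor count, or net charge, is enough to move this read-out. Nothing at hand bears on the origin of this step.

From the compounds shown here alone, whether hydrogen, methoxy or an amine at this place would extend the trend remains open. So does whether the same exchange has a comparable effect on the other phenyl groups.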